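This account rests on a few compounds, and the source may have more. Where it says the series, first, only, none or still open, it means among the compounds named here.

Compound 1 `Cc1cc(C)c(-c2nc(CN3CCC(C(=O)NCCCN4C[C@H](C)C[C@H](C)C4)CC3)c(C)o2)c(C)c1` gives 6570 nM in an ADME assay on Huh7.5.1 cells (Homo sapiens) for cytotoxicity, read by ATP content, with a stated time of 48 h; on this read-out lower numbers stand for higher toxicity in this test and higher numbers for lower toxicity in this test.
Compound 2 `Cc1ccccc1-c1nc(CN2CCC(C(=O)NCCCN3CCC(C)(C)CC3)CC2)c(C)o1` gives 10200 nM in this assay.
Compound 3 `Cc1ccccc1-c1nc(CN2CCC(C(=O)NCCCN3CCCCC3)CC2)c(C)o1` gives 18100 nM in this assay.

Compound 1 stands at the low end of these three numbers. Its gap to compound 2 is within the usual scatter of repeated measurements, so the two cannot be told apart, while compound 3 lies beyond the scatter above compound 1.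

Compound 4 `Cc1ccc(-c2nc(CN3CCC(C(=O)NCCCN4C[C@H](C)C[C@H](C)C4)CC3)c(C)o2)cc1` has not yet been measured in this assay. It differs from compound 1 in one place: 4-methylphenyl in place of 2,4,6-trimethylphenyl on an aromatic carbon. Within the data shown here, the only step measured between two compounds that differ in one place is a 1.8-fold higher number from compound 2 to compound 3 (0.25 log units; within the scatter), and that step changes the saturated ring at the far end of the chain, not the aromatic ring altered here; it offers no direct guide. Compound 2 and compound 3 differ from compound 1 in more than one place, so their values show only that varied substitution on the shared core has so far kept the numbers within a narrow band.

Among the measured compounds shown here, with no step bearing directly on this change, compound 4 is expected to give about 8000 nM, between 3500 nM and 20000 nM, and the estimated step of a 1.2-fold higher number from compound 1 to compound 4 (0.09 log units; within the scatter) is expected to stay within the scatter.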

Compound 4, half-maximal cytotoxic concentration: 4330 nM
Compound 4: middle estimate off by 1.8-fold (0.27 log units), on the high side; measured number inside the range.
By their numbers in this assay, from the lowest: compounds 4, 1, 2 and 3 (each within the scatter of the next, the first and the last beyond it).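

In this assay, replacing 2,4,6-trimethylphenyl with 4-methylphenyl gives a 1.5-fold lower number from compound 1 to compound 4 (0.18 log units; within the scatter), so compound 1 and compound 4 cannot be told apart. This is the first step shown at this position, an aromatic carbon of the five-membered aromatic ring with 1 nitrogen and 1 oxygen; the earlier step changed only the saturated ring at the far end of the chain. Going from a group of 9 heavy atoms to one of 7, both carbon-only aromatic rings without hydrogen-bond donors or acceptors, therefore leaves the number in this test within the usual scatter, although no measurement here accounts for that result.

Among these compounds, this single step covers only two methyl-substituted phenyl groups, so it remains open whether plain phenyl, 4-methoxyphenyl, 4-chlorophenyl or a pyridyl ring at this position would also stay within the scatter of compound 1. It also leaves open whether a carboxylic acid or an amine on this aromatic ring would give a step beyond the scatter.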